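This account rests on a few compounds, and the source may have more. Where it says the series, first, only, none or still open, it means among the compounds named here.

Compound 1 `COc1ncc(-c2ccc3c(c2)N(c2ccc(C)cc2)C(=O)CO3)cc1NS(=O)(=O)c1ccc(F)cc1` gives 12900 nM in a functional assay on A-375 cells (Homo sapiens) for antiproliferative activity, read by MTT assay, with a stated time of 72 h; on this read-out higher numbers stand for weaker inhibition and lower numbers for stronger inhibition. Compound 2 `COc1ccc(N2C(=O)COc3ccc(-c4cnc(OC)c(NS(=O)(=O)c5ccc(F)cc5)c4)cc32)cc1` gives 18400 nM in this assay. Compound 3 `COc1ncc(-c2ccc3c(c2)NC(=O)CO3)cc1NS(=O)(=O)c1ccc(F)cc1` gives 26300 nM in this assay.

Among the three measured compounds, compound 3 carries the highest number. Its nearest neighbour is compound 2, and a 1.4-fold higher number from compound 2 to compound 3 (0.16 log units; within the scatter) stays within the scatter. Its furthest neighbour is compound 1, and a 2.0-fold higher number from compound 1 to compound 3 (0.31 log units; beyond the scatter) lies beyond the scatter, though only modestly. Both of those steps concern the same site, the amide-type nitrogen in the ring, where the two aryl groups of compound 1 and compound 2 are replaced by hydrogen in compound 3.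

Compound 4 `COc1ncc(-c2ccc3c(c2)N(C(C)C)C(=O)CO3)cc1NS(=O)(=O)c1ccc(F)cc1` returns to that site: isopropyl in place of hydrogen on an amide-type nitrogen in a ring. The two steps that touch this nitrogen point in a consistent direction, with a substituent giving a lower number than hydrogen, but the effect is modest in one case and within the scatter in the other, and neither step involves an alkyl group of this size. A small downward step, or none beyond the scatter, is therefore the reasonable expectation in this assay.

For compound 4, the estimated value is 18000 nM, within a range of 8500 nM to 40000 nM, which is expected to correspond to a 1.5-fold lower number from compound 3 to compound 4 (0.16 log units; within the scatter).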

Compound 4, half-maximal inhibitory concentration: 9950 nM
For compound 4 the middle estimate is 1.8-fold (0.26 log units) above the measured one; low and high end bracket the measured number.
By their numbers in this assay, from the lowest: compounds 4, 1, 2 and 3 (each within the scatter of the next, the first and the last beyond it).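

Isopropyl on the amide-type nitrogen gives, in this assay, a 2.6-fold lower number from compound 3 to compound 4 (0.42 log units; beyond the scatter), so a small alkyl group with no ring and no hydrogen-bond donors or acceptors is enough to move the number beyond the scatter relative to hydrogen. Set against the aryl-bearing compounds, isopropyl cannot be told apart from either group, with a 1.8-fold lower number from compound 2 to compound 4 (0.27 log units; within the scatter) and a 1.3-fold lower number from compound 1 to compound 4 (0.11 log units; within the scatter), which shows that a substituent here need not be aromatic to match them, while compound 2 itself remains within the scatter of compound 3. No measurement shown bears on why the number responds to this change at this nitrogen.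

Going by these compounds, it stays open how far this position tolerates other groups: whether methyl, a longer chain such as n-butyl, or a chain ending in an amine or a carboxylic acid would follow isopropyl or part from it. On these data alone, it is also open whether the step from hydrogen to isopropyl would keep its size on a core with a different group in place of the 4-fluorophenyl sulfonamide, since all four compounds share that part.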